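Working notes: nitro to methylsulfanyl on the aryl urea

A few compounds are considered here, and "the series" means these few. Any claim that something is new, unique, unknown or untested is made for them only; others in the source may bear on it.

Measured so far in a functional assay on CRL2813 cells (Homo sapiens) for cytotoxicity, read by sulforhodamine B assay, with a stated time of 5 days; on this read-out higher numbers stand for weaker inhibition and lower numbers for stronger inhibition:
compound 1 `O=C(Nc1ccc(Cl)cc1)N[C@H]1CC[C@H](Oc2ccc(F)cc2)CC1` gives > 20000 nM; this is a limit of the assay, not a number.
compound 2 `O=C(Nc1ccc([N+](=O)[O-])cc1)N[C@H]1CC[C@H](Oc2ccc(F)cc2)CC1` gives 2300 nM.

Among the compounds with values here, compound 2 holds the only number in this assay; the other value shown is a limit. Within the data shown here, the single measured step, an at least 8.6-fold lower number from compound 1 to compound 2 (0.93 log units; beyond the scatter), rests on the limit of > 20000 nM in this assay, at which 1 of the 2 values shown sits, and therefore gives only a lower bound on its true size.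

Compound 3 `CSc1ccc(NC(=O)N[C@H]2CC[C@H](Oc3ccc(F)cc3)CC2)cc1` differs from compound 2 as follows: methylsulfanyl in place of nitro on an aromatic carbon. Among the measured compounds shown here, no measured step covers this exchange directly. Chloro in compound 1 reached only the limit, nitro in compound 2 gave the sole number, and methylsulfanyl is untested in this series. Going by these compounds, since the move from chloro to nitro was at least modest, a move away from nitro is expected to give a higher number again, though how far remains open. Compound 3 is therefore expected to show a 3.5-fold higher number from compound 2 to compound 3 (0.54 log units; beyond the scatter) in this assay. For compound 3 the estimate in this assay is 8000 nM, with a range from 2000 nM to 30000 nM, and a real chance that only a limit is returned.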

Compound 3, half-maximal inhibitory concentration: > 20000 nM
Compound 3: only a limit was reported (the forecaster's own chance of this, stated with the estimate: 35%); middle value at least 2.5-fold (0.39 log units) away from the limit.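

In this assay, methylsulfanyl in place of nitro on an aromatic carbon, para to a large group, gives an at least 8.6-fold higher number from compound 2 to compound 3 (0.93 log units; beyond the scatter). Nitro now stands apart from two different replacements rather than one, so within these three compounds a measurable number at this position occurs only with the nitro group of compound 2. Compound 1 and compound 3 each return a limit and not a number, so the step between them cannot be read, and the step from nitro to methylsulfanyl gives only a lower bound, because these comparisons rest on the same limit: the limit of > 20000 nM in this assay, at which 2 of the 3 values shown sit.

Going by these compounds, whether a number at this position is peculiar to nitro remains open; a nitrile, a trifluoromethyl or an amine on the same aromatic carbon of the shared core would test this. How far chloro and methylsulfanyl lie from each other also stays unresolved, as does whether the step from nitro to methylsulfanyl holds with a group other than the 4-fluorophenoxy of these compounds, such as a plain phenoxy.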